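Adding a methoxy to the core of compound 3

This account rests on a few compounds, and the source may have more. Where it says the series, first, only, none or still open, it means among the compounds named here.

Measured so far in a functional assay on MCF7 cells (Homo sapiens) for antiproliferative activity, read by sulforhodamine B assay, with a stated time of 72 h; on this read-out lower numbers stand for stronger inhibition and higher numbers for weaker inhibition:
compound 1 `COc1cc2occ(-c3csc4ccccc34)c(=O)c2c(OC)c1OC`, 740 nM
compound 2 `CCOc1c(OC)cc2occ(-c3csc4ccccc34)c(=O)c2c1OC`, 4000 nM
compound 3 `COc1cc2occ(-c3csc4ccccc34)c(=O)c2cc1OC`, > 10000 nM

The value of compound 3 is a limit of the assay, not a number, as the limit of > 10000 nM in this assay, at which 1 of the 3 values shown sits, notes; among the three compounds it sits at the weak end. Compound 4 `COc1cc2c(=O)c(-c3csc4ccccc34)coc2c(OC)c1OC` differs from compound 3 by methoxy in place of hydrogen on an aromatic carbon. The step that bears on this is an at least 13-fold higher number from compound 1 to compound 3 (1.13 log units; beyond the scatter), a large loss on removing a methoxy from the core; a 5.4-fold higher number from compound 1 to compound 2 (0.73 log units; beyond the scatter) is a smaller change elsewhere. The methoxy entering compound 4 sits at a different place than the one lost there, so the gain is expected to be only partial: the step is estimated as an at least 3.3-fold lower number from compound 3 to compound 4 (0.52 log units; beyond the scatter), with compound 4 expected near 3000 nM (range 800 nM to 10000 nM).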

Compound 4, half-maximal inhibitory concentration: > 10000 nM
Compound 4 ended at the assay's limit (the forecaster's own chance of this, stated with the estimate: 30%); at least 3.3-fold (0.52 log units) between middle value and limit.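

No step from compound 3 to compound 4 can be read, since both stand at the same limit of the assay: the limit of > 10000 nM in this assay, at which 2 of the 4 values shown sit.

The compounds shown leave open whether the methoxy entering compound 4 changes the activity at all.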